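Swapping the bicyclic core of a sulfonyl benzylamide

The source may report more compounds than this note shows. Statements on the series, on what has been measured and on what is new or still open speak of the compounds shown alone.

Of the compounds shown here, three sharing one amide-linked scaffold have been tested in a functional assay on A2780 cells (Homo sapiens) for inhibition, read by sulforhodamine B assay, with a stated time of 72 h; on this read-out lower numbers stand for stronger inhibition and higher numbers for weaker inhibition. Compound 1 `O=C(NCc1ccc(S(=O)(=O)N2CCCCC2)cc1)c1cnc2nccn2c1` carries a piperidin-1-yl group on its sulfonyl sulfur, and in this assay compound 1 gives 130 nM. Compound 2 `O=C(NCc1ccc(S(=O)(=O)c2cccc(C(F)(F)F)c2)cc1)c1cnc2nccn2c1` gives 2 nM, and compound 3 `O=C(NCc1ccc(S(=O)(=O)c2ccccc2)cc1)c1cnc2nccn2c1` gives 68 nM. Compound 1 thus stands at the highest, weakest end of the three: the step of a 65-fold lower number from compound 1 to compound 2 (1.81 log units; beyond the scatter) is large, whereas the step of a 1.9-fold lower number from compound 1 to compound 3 (0.28 log units; within the scatter) is within the scatter; between the two aryl sulfones, the step of a 34-fold higher number from compound 2 to compound 3 (1.53 log units; beyond the scatter) is again large.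

Compound 4 `O=C(NCc1ccc(S(=O)(=O)N2CCCCC2)cc1)c1ccn2ccnc2c1` keeps the whole sulfonyl side of compound 1 unchanged and instead alters the core. The difference is a group of 9 heavy atoms (7 carbon, 2 nitrogen; one five-membered aromatic ring with 2 hetero atoms, one six-membered aromatic ring with 1 hetero atom) in place of a group of 9 heavy atoms (6 carbon, 3 nitrogen; one five-membered aromatic ring with 2 hetero atoms, one six-membered aromatic ring with 2 hetero atoms), on a carbonyl carbon. Going by the values given here, none of the measured steps touches this position; all three concern the sulfonyl substituent, so they give no direct guide to the size or direction of a change at the carbonyl end. With nothing to show that the core swap matters, a step of about a 1.2-fold higher number from compound 1 to compound 4 (0.06 log units; within the scatter) is expected, that is, no clear change beyond the scatter. Compound 4 is therefore estimated at 150 nM, with a wide range from 40 nM to 600 nM to reflect this uncertainty.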

Compound 4, half-maximal inhibitory concentration: > 10000 nM
Compound 4 ended at the assay's limit (the forecaster's own chance of this, stated with the estimate: 5%); middle value at least 66-fold (1.82 log units) from the limit.
By their numbers in this assay, from the lowest: compound 2; then compounds 3 and 1 (each within the scatter of the next). At a limit, above all of these: compound 4.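

Going by these compounds alone, until now every measured step concerned the sulfonyl substituent, and this is the first to show that the group on the carbonyl carbon also decides the outcome. With the whole sulfonyl side held fixed, replacing a core whose six-membered aromatic ring has 2 hetero atoms with one whose six-membered aromatic ring has 1 hetero atom, at the same count of 9 heavy atoms, gives an at least 76-fold higher number from compound 1 to compound 4 (1.88 log units; beyond the scatter), so large steps in this series are not confined to the sulfonyl end. The result for compound 4 in this assay is a limit of the assay and not a number: the limit of > 10000 nM in this assay, at which 1 of the 4 values shown sits.

The compounds shown pair this altered core only with piperidin-1-yl on the sulfonyl sulfur, so it stays open whether the same swap would cost as much alongside the 3-(trifluoromethyl)phenyl group of compound 2 or the phenyl group of compound 3. Also open, from the compounds shown here alone, is whether an amine or a carboxylic acid attached to the core of compound 4 would bring back any inhibition.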